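The source may report more compounds than this note shows. Statements on the series, on what has been measured and on what is new or still open speak of the compounds shown alone.

Working notes on the series. The shared core carries a hydroxyphenyl group, a chlorophenyl group and a third aryl group. Compound 1 `Oc1cccc(-c2cc(-c3cccnc3)nc(-c3cccc(Cl)c3)c2)c1` gives "not determined" (no result reported) in an ADME assay on HEK293 cells (Homo sapiens) for cytotoxicity, read by CCK-8 assay and cell counting, with a stated time of 2 days; on this read-out higher numbers stand for weaker inhibition and lower numbers for stronger inhibition. Compound 2 `Oc1ccc(-c2cc(-c3ccccc3)nc(-c3ccccc3Cl)c2)cc1` gives 3930 nM in this assay. Compound 3 `Oc1ccc(-c2cc(-c3cccnc3)nc(-c3cccc(Cl)c3)c2)cc1` gives 25700 nM in this assay. Compound 2 thus stands at the lowest of the two numbers; its gap to compound 3 is beyond the usual scatter, but the two compounds differ in more than one place, so no single change can be tied to that gap.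

Compound 4 `Oc1ccc(-c2cc(-c3ccsc3)nc(-c3ccccc3Cl)c2)cc1` differs from compound 2 in one place: thiophen-3-yl in place of phenyl on an aromatic carbon. For the measured compounds named here, no step between measured compounds isolates this change, and no measured pair exchanges the third aryl group alone. With nothing in the numbers pointing either way, no step beyond the scatter is expected from compound 2 to compound 4, so the expected value for compound 4 is 4500 nM, within the range 1500 nM to 14000 nM. The step this estimate implies is a 1.1-fold higher number from compound 2 to compound 4 (0.06 log units; within the scatter), which is expected to lie within the scatter, though the range allows for a moderate shift in either direction.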

Compound 4, half-maximal inhibitory concentration: 5930 nM
The estimate for compound 4 lay 1.3-fold (0.12 log units) below the measured number; measured number inside the range.
By their numbers in this assay, from the lowest: compounds 2 and 4 (each within the scatter of the next); then compound 3.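

For the compounds shown here, this is the first single-place comparison: in this assay, thiophen-3-yl in place of phenyl on an aromatic carbon gives a 1.5-fold higher number from compound 2 to compound 4 (0.18 log units; within the scatter) at this position. With the 2-chlorophenyl and 4-hydroxyphenyl groups held constant, the six-membered aromatic ring of carbon only can therefore be exchanged for a five-membered aromatic ring with a hetero atom without a step beyond the scatter. No measurement in hand gives a reason for this outcome.

Still open, from the compounds shown here alone, is whether a non-aromatic group at this position, such as an amine, a carboxylic acid or a longer alkyl chain, would also stay within the scatter. Also open, going by these compounds, is whether the same exchange would give a similar step with the chlorine placed elsewhere on the chlorophenyl group.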